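Extending the Saturated Chain of Compound 3

The source may hold more compounds than are shown below. What is called first, only, known or untested is meant among the compounds shown, and "the series" means these compounds.

Three related structures appear in an ADME assay on MRC5 cells (Homo sapiens) for inhibition, read by MTT assay, with a stated time of 72 h (a higher number here means a weaker inhibitor, a lower number a stronger inhibitor), but only one of them comes with a number. Compound 1 `O=C(OCCO)OCCc1ccc(O)c(O)c1` carries the entry "not determined" (no result reported), and compound 2 `O=C(OCCCCO)OCCc1ccc(O)c(O)c1` carries the entry "not determined" (no result reported). Going by the values given here, compound 3 `CCCCCCOC(=O)OCCc1ccc(O)c(O)c1` gives 11200 nM, the only measured value here, so it cannot yet be ranked against any relative.

Compound 4 `CCCCCCCCOC(=O)OCCc1ccc(O)c(O)c1` has still to be measured. Its structure departs from compound 3 by ethyl in place of hydrogen on a saturated chain carbon, six bonds along the chain from an oxygen next to a carbonyl group. The result is a longer chain, with the shared core untouched.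

Among the compounds with values here, no measured pair shows what such a change does in this assay, so any forecast is uncertain. A modest move towards a stronger inhibitor seems likeliest, close to the usual scatter or slightly beyond it. The expected change is a 1.6-fold lower number from compound 3 to compound 4 (0.20 log units; within the scatter). For compound 4, the estimated value is 7000 nM, with an expected range of 2500 nM to 20000 nM.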

Compound 4, half-maximal inhibitory concentration: 37900 nM
Estimate against measurement, compound 4: 5.4-fold (0.73 log units) below; measured number outside the range, above it.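

In this assay, ethyl in place of hydrogen on a saturated chain carbon, six bonds along the chain from an oxygen next to a carbonyl group, gives a 3.4-fold higher number from compound 3 to compound 4 (0.53 log units; beyond the scatter), so this longer chain goes with weaker inhibition, not stronger. Going by these compounds alone, this is the first change here that can be read as a step, and because it lies beyond the usual scatter, it shows that the assay responds to a change at this position. Nothing shown explains why the number rises.

A single step cannot show whether a still longer chain would raise the number further or reverse the direction. Also open, from the compounds shown here alone, is how an amine or a carboxylic acid in place of the ethyl would compare.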